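The compounds below may be only part of what the source reports. "The series", "measured", "known", "first", "only" and "open" are said of these compounds alone.

Values in a functional assay on HeLa cells for agonist activity at 5-hydroxytryptamine receptor 6 (Homo sapiens), read by immunoassay; on this read-out lower numbers stand for smaller maximal responses and higher numbers for larger maximal responses:
compound 1 `CN(C)CCn1cc(S(=O)(=O)c2ccccc2)c2cccnc21`: 94%
compound 2 `CN(C)CCn1cc(S(=O)(=O)c2cc(Cl)cc(Cl)c2)c2cccnc21`: 80%
compound 3 `CN(C)CCn1cc(S(=O)(=O)c2c(Cl)cccc2Cl)c2cccnc21`: 66%

Compound 3 stands lowest of the three numbers. Its nearest neighbour is compound 2 and its furthest is compound 1; the gaps are a number 14 percentage points lower from compound 2 to compound 3 (beyond the scatter) and a number 28 percentage points lower from compound 1 to compound 3 (beyond the scatter). Both gaps lie beyond the scatter.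

Compound 4 `CN(C)CCn1cc(S(=O)(=O)c2cccs2)c2cccnc21` is the next step: thiophen-2-yl in place of 2,6-dichlorophenyl on a sulfonyl sulfur.

Within the data shown here, no measured step puts a thiophen-2-yl onto the sulfonyl sulfur, so the change is not covered directly. Among the measured compounds shown here, the steps that bear on it are the ones that put chlorine onto the phenyl, a number 14 percentage points lower from compound 1 to compound 2 (beyond the scatter) and a number 28 percentage points lower from compound 1 to compound 3 (beyond the scatter), both modest and both downward. Going by these compounds, compound 4 removes the 2,6-dichlorophenyl, so the change runs against the step from compound 1 to compound 3, and a rise back toward the level of compound 1 is expected, with wide uncertainty since the thiophen-2-yl itself is untested. The expected step for compound 4 is a number 19 percentage points higher from compound 3 to compound 4 (beyond the scatter). Compound 4 is estimated at 85%, within a range of 68% to 100%.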

Compound 4, largest response reached (Emax), in percent of the reference or control that the assay uses: 74%
Compound 4: middle estimate off by 11 percentage points, on the high side; measured number inside the range.
By their numbers in this assay, from the lowest: compounds 3, 4 and 2 (each within the scatter of the next, the first and the last beyond it); then compound 1.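

Notes on the sulfonyl sulfur position in this assay: replacing the six-membered aromatic ring with a five-membered one lowers the response without any chlorine present, with a number 20 percentage points lower from compound 1 to compound 4 (beyond the scatter). Chlorine is therefore not required for a step down from compound 1 at this position. The thiophen-2-yl group also does not separate from either dichlorophenyl group, with a number 8 percentage points higher from compound 3 to compound 4 (within the scatter) and a number 6 percentage points lower from compound 2 to compound 4 (within the scatter), so removing the 2,6-dichlorophenyl group does not restore the level of compound 1. No evidence available here bears on what underlies these differences.

Going by these compounds, whether a furan-2-yl or pyridin-3-yl group on the sulfonyl sulfur would stay level with compound 4 or approach compound 1 remains open. On these data alone, the effect of replacing the dimethylamine with a pyrrolidine, with the sulfonyl group held constant, also remains open.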